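The source may hold more compounds than are shown below. What is called first, only, known or untested is meant among the compounds shown, and "the series" means these compounds.

Measured so far in a functional assay on BGC-823 cells (Homo sapiens) for inhibition, read by MTT assay, with a stated time of 72 h; a lower number here means a stronger inhibitor, a higher number a weaker inhibitor:
- compound 1 `Cc1ccc(N2CCCC2)c(C(=O)Nc2ccc(CNC(=O)OCc3cccnc3)cc2)c1`: > 100000 nM, a limit
- compound 2 `O=C(NCc1ccc(NC(=O)c2cc(-c3ccccc3)ccc2N2CCCC2)cc1)OCc1cccnc1`: > 100000 nM, a limit
- compound 3 `O=C(NCc1ccc(NC(=O)c2cc(F)ccc2N2CCCC2)cc1)OCc1cccnc1`: 14800 nM

For the measured compounds named here, compound 3 holds the only real number. The other two values are not numbers but a limit of the assay: the limit of > 100000 nM in this assay, at which 2 of the 3 values shown sit.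

The next step leads to compound 4 `COc1ccc(N2CCCC2)c(C(=O)Nc2ccc(CNC(=O)OCc3cccnc3)cc2)c1`: methoxy in place of fluoro on an aromatic carbon, para to a pyrrolidin-1-yl group. Two measured steps at this same carbon bear on it. Fluoro in place of methyl gives an at least 6.7-fold lower number from compound 1 to compound 3 (0.82 log units; beyond the scatter), and fluoro in place of phenyl gives an at least 6.7-fold lower number from compound 2 to compound 3 (0.82 log units; beyond the scatter). The remaining step, a step that the two limits leave unreadable from compound 1 to compound 2, adds nothing.

Among these three compounds, neither replacement of fluoro keeps a measurable number, and no compound goes against this. Methoxy itself is untested here, so a higher number is expected rather than certain, because an at least 6.7-fold lower number from compound 1 to compound 3 (0.82 log units; beyond the scatter) is the closest guide. In this assay the expected move is a 2.7-fold higher number from compound 3 to compound 4 (0.43 log units; beyond the scatter). A report of only a limit is a real possibility. For compound 4 the estimated value is 40000 nM, with an expected range from 10000 nM to 100000 nM.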

Compound 4, half-maximal inhibitory concentration: > 100000 nM
Compound 4 was reported as a limit; the forecaster's own chance of this, stated with the estimate: 45%; middle value at least 2.5-fold (0.39 log units) away from the limit.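

In this assay, methoxy now joins methyl and phenyl on the aromatic carbon para to a pyrrolidin-1-yl group as a replacement for fluoro that gives no measurable number: an at least 6.7-fold higher number from compound 3 to compound 4 (0.82 log units; beyond the scatter). The gain of an oxygen-linked group with one hydrogen-bond acceptor therefore does not preserve the number held by compound 3, so among the four groups shown, only fluoro gives a real number at this carbon, and that number is weak and stands alone: the limit of > 100000 nM in this assay, at which 3 of the 4 values shown sit. The steps among compound 1, compound 2 and compound 4 cannot be read, so methyl, phenyl and methoxy cannot be ordered.

Chloro, a nitrile or an amine on the same carbon could show whether a measurable number belongs to fluoro alone. The shared core also leaves open how far any group at this carbon could lower the number.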